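Replacing the nitrophenyl group: what to expect for compound 4

This account rests on a few compounds, and the source may have more. Where it says the series, first, only, none or still open, it means among the compounds named here.

Three compounds share one core and differ only in the aromatic group attached to an amine nitrogen in a ring. In a functional assay on CHO cells with adenosine receptor A1 (Homo sapiens) as the target, read by cAMP accumulation and immunoassay, with a stated time of 6 min, tested at 10 uM (on this read-out lower numbers stand for a stronger effect and higher numbers for a weaker effect at the one concentration tested), compound 1 `Nc1scc(CN2CCN(c3ccc([N+](=O)[O-])cc3)CC2)c1C(=O)c1ccc(Cl)cc1` gives -17%, the highest of the three numbers. Compound 2 `Nc1scc(CN2CCN(c3ccc(Cl)c(C(F)(F)F)c3)CC2)c1C(=O)c1ccc(Cl)cc1` gives -60%, and compound 3 `Nc1scc(CN2CCN(c3cccc(F)c3)CC2)c1C(=O)c1ccc(Cl)cc1` gives -82%. Both replacements of the 4-nitrophenyl group pushed the number down: a number 43 percentage points lower from compound 1 to compound 2 (beyond the scatter), and a number 65 percentage points lower from compound 1 to compound 3 (beyond the scatter); between the two new groups, a number 22 percentage points lower from compound 2 to compound 3 (beyond the scatter).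

Compound 4 `Nc1scc(CN2CCN(c3c(F)cc(F)cc3F)CC2)c1C(=O)c1ccc(Cl)cc1` has not yet been measured. It differs from compound 1 in one place: 2,4,6-trifluorophenyl in place of 4-nitrophenyl on an amine nitrogen in a ring. Here again the 4-nitrophenyl group leaves and another halogen-bearing phenyl enters, so the two measured steps away from compound 1 bear directly on this case, and both were large and downward. A step of similar size in the same direction is therefore expected. The number expected for compound 4 is -55%, within -85% to -25%, which would mean an expected step of a number 38 percentage points lower from compound 1 to compound 4 (beyond the scatter). Among the compounds with values here, only three measured compounds stand behind this expectation, so the range is kept wide.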

Compound 4, a percentage reported as activity, at one concentration (the size of the read-out at that concentration, not a potency): -78%
Estimate against measurement, compound 4: 23 percentage points above; measured number inside the range.
By their numbers in this assay, from the lowest: compounds 3 and 4 (each within the scatter of the next); then compound 2; then compound 1.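

The step to the 2,4,6-trifluorophenyl group, a number 61 percentage points lower from compound 1 to compound 4 (beyond the scatter), is a third large move in the same direction, so all three replacements of the 4-nitrophenyl group on this ring nitrogen now lower the number. Changing the fluorine pattern on the ring makes little difference in this assay: the reading shows a number 4 percentage points higher from compound 3 to compound 4 (within the scatter), so the 3-fluorophenyl and 2,4,6-trifluorophenyl groups cannot be told apart here. Both fluorophenyl compounds stand apart from the 4-chloro-3-(trifluoromethyl)phenyl compound, as the step of a number 18 percentage points lower from compound 2 to compound 4 (beyond the scatter) shows alongside the earlier gap to compound 3.

Nothing available explains why these groups differ. From the compounds shown here alone, it also remains open whether an unsubstituted phenyl, or a phenyl carrying a methoxy group or a nitrile, would read like compound 4 or like compound 1.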